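Aryl-triazole variation on the spiro-oxindole series

The compounds below may be only part of what the source reports. "The series", "measured", "known", "first", "only" and "open" are said of these compounds alone.

Compound 3 `COc1ccc(OC)c(-n2nncc2CN2C(=O)C3(C(C#N)=C(N)Oc4c(N)cc5nc6ccccc6nc5c43)c3ccccc32)c1` stands at the edge of what a functional assay on HCT-116 cells (Homo sapiens) for antiproliferative activity, read by MTT assay, with a stated time of 48 h (on this read-out higher numbers stand for weaker inhibition and lower numbers for stronger inhibition), reports: compound 3 gives > 50000 nM, which is a limit of the assay and not a number. Compound 1 `Cc1cccc(-n2nncc2CN2C(=O)C3(C(C#N)=C(N)Oc4c(N)cc5nc6ccccc6nc5c43)c3ccccc32)c1` is the same; in this assay compound 1 gives > 50000 nM, again a limit. Within the data shown here, compound 2 `N#CC1=C(N)Oc2c(N)cc3nc4ccccc4nc3c2C12C(=O)N(Cc1cnnn1-c1cccc(C(F)(F)F)c1)c1ccccc12` is the only member with a number, as in this assay compound 2 gives 18900 nM. The measured steps are an at least 2.6-fold lower number from compound 1 to compound 2 (0.42 log units; beyond the scatter), an at least 2.6-fold higher number from compound 2 to compound 3 (0.42 log units; beyond the scatter) and a step that the two limits leave unreadable from compound 1 to compound 3; two of the three values sit at the limit of > 50000 nM in this assay, at which 2 of the 3 values shown sit.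

Compound 4 `Cc1ccc(Cl)cc1-n1nncc1CN1C(=O)C2(C(C#N)=C(N)Oc3c(N)cc4nc5ccccc5nc4c32)c2ccccc21` differs from compound 3 in one place: 5-chloro-2-methylphenyl in place of 2,5-dimethoxyphenyl on an aromatic nitrogen. Among the measured compounds shown here, compound 4 thereby carries the methyl of compound 1 with an added chlorine, so the bearing steps are an at least 2.6-fold higher number from compound 2 to compound 3 (0.42 log units; beyond the scatter) and an at least 2.6-fold lower number from compound 1 to compound 2 (0.42 log units; beyond the scatter); the only change that left the limit was trifluoromethyl in place of methyl. A small downward step, an at least 1.2-fold lower number from compound 3 to compound 4 (0.09 log units; that floor lies within the scatter), is expected for compound 4, most probably still ending at the limit. The estimate for compound 4 is 40000 nM, with a range of 12000 nM to 80000 nM.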

Compound 4, half-maximal inhibitory concentration: 37200 nM
Compound 4: middle estimate off by 1.1-fold (0.03 log units), on the high side; low and high end bracket the measured number.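

In this assay, 5-chloro-2-methylphenyl on this aromatic nitrogen gives a measured number, so the 3-(trifluoromethyl)phenyl of compound 2 is no longer the only group here to leave the assay limit, which for compound 1 and compound 3 remains a limit and not a number: the limit of > 50000 nM in this assay, at which 2 of the 4 values shown sit.

The steps from those two compounds are an at least 1.3-fold lower number from compound 3 to compound 4 (0.12 log units; that floor lies within the scatter) and an at least 1.3-fold lower number from compound 1 to compound 4 (0.12 log units; that floor lies within the scatter), so each gives only a floor, and neither floor is beyond the scatter. The remaining step is a 2.0-fold higher number from compound 2 to compound 4 (0.29 log units; within the scatter), so compound 2 and compound 4 cannot be ordered.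

Open, as far as these compounds go, is whether an aryl group carrying an amine or a carboxylic acid on this nitrogen would move the number beyond the scatter from compound 2. Also open, from the compounds shown here alone, is how much of the result for compound 4 belongs to the chlorine and how much to the methyl.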